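Vero cell tolerance notes, compounds 1 to 3

A few compounds are considered here, and "the series" means these few. Any claim that something is new, unique, unknown or untested is made for them only; others in the source may bear on it.

Measured so far:
compound 1 `O=c1nc(N2CCN(NC3CCCCC3)CC2)sc2c([N+](=O)[O-])cc(C(F)(F)F)cc12`: > 64 ug/mL
compound 2 `O=c1nc(N2CCN(NCc3ccc(F)cc3)CC2)sc2c([N+](=O)[O-])cc(C(F)(F)F)cc12`: > 64 ug/mL

Compound 1 stands only at a limit in an ADME assay on Vero cells (Chlorocebus sabaeus) for cytotoxicity, read by MTT assay, with a stated time of 72 h; a lower number here means that less compound is tolerated, a higher number that more compound is tolerated: its value of > 64 ug/mL is a limit of the assay and not a number. Compound 2 in this assay likewise gives > 64 ug/mL, again a limit. Within the data shown here, the one measured step, a step that the two limits leave unreadable from compound 1 to compound 2, is therefore unreadable in size; both values sit at the limit of > 64 ug/mL in this assay, at which 2 of the 2 values shown sit, so nothing is known of the gap between them beyond the fact that neither compound shows toxicity up to the limit.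

Compound 3 `Cc1cccc(F)c1CNN1CCN(c2nc(=O)c3cc(C(F)(F)F)cc([N+](=O)[O-])c3s2)CC1` has not yet been measured. It differs from compound 1 as follows: 2-fluoro-6-methylbenzyl in place of cyclohexyl on an amine nitrogen. Among the measured compounds shown here, the only measured step that bears on it is the unreadable one from compound 1 to compound 2, which swaps the same cyclohexyl for a different benzyl group at the same amine nitrogen. No step beyond the scatter is expected for a number no higher from compound 1 to compound 3 (the limit leaves the size open), and compound 3 is most likely to remain at the limit as well. The estimate for compound 3 in this assay is 64 ug/mL, with a range from 40 ug/mL to 128 ug/mL.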

Compound 3, half-maximal cytotoxic concentration: > 64 ug/mL
Compound 3: no number, only a limit (the forecaster's own chance of this, stated with the estimate: 80%); the middle value sits exactly at the limit.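

In this assay compound 3 gives > 64 ug/mL, a limit of the assay and not a number. No step among compound 1, compound 2 and compound 3 can be read, because all three stand at the same limit: the limit of > 64 ug/mL in this assay, at which 3 of the 3 values shown sit.

The compounds shown leave open whether cyclohexyl, 4-fluorobenzyl and 2-fluoro-6-methylbenzyl differ at all in this assay.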